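The source may hold more compounds than are shown below. What is called first, only, known or untested is meant among the compounds shown, and "the series" means these compounds.

Of the compounds shown here, two of a shared core have so far been measured in a functional assay on NCI-H3122 cells (Homo sapiens) for antiproliferative activity, read by MTT assay, with a stated time of 48 h; on this read-out higher numbers stand for weaker inhibition and lower numbers for stronger inhibition. Compound 1 `COc1cccc(CNC(=O)c2cccc(C(C)Oc3cccnc3Nc3cnn(C)c3)c2)c1` gives 49400 nM. Compound 2 `Cc1ccc(CNC(=O)c2cccc(C(C)Oc3ccnc(Nc4cnn(C5CCN(C)CC5)c4)c3)c2)cc1` gives 8900 nM, the lower of the two numbers; the number of compound 1 stands higher than that of compound 2 by a margin beyond the scatter, so compound 2 is the stronger inhibitor of the two on this assay. For the measured compounds named here, the two compounds differ in several places at once, so no single step between them can be read off.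

Compound 3 `CC(Oc1ccnc(Nc2cnn(C3CCN(C)CC3)c2)c1)c1cccc(C(=O)NCc2ccc(Cl)c(C(F)(F)F)c2)c1` has not yet been measured. It differs from compound 2 in one place only: 4-chloro-3-(trifluoromethyl)phenyl in place of 4-methylphenyl on a saturated chain carbon bound to an amide-type nitrogen. Going by the values given here, there is no measured pair in this set that isolates such a change, so the expectation for compound 3 rests on the position of compound 2 alone. A step from compound 2 to compound 3 of no more than the scatter is expected, with the estimated step of a 1.5-fold lower number from compound 2 to compound 3 (0.17 log units; within the scatter) leaning slightly toward a lower number. On this basis compound 3 is expected to give about 6000 nM in this assay, within a range from 1500 nM to 25000 nM.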

Compound 3, half-maximal inhibitory concentration: 8000 nM
Estimate against measurement, compound 3: 1.3-fold (0.12 log units) below; the range from low to high includes it.
By their numbers in this assay, from the lowest: compounds 3 and 2 (each within the scatter of the next); then compound 1.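

In this assay, for the compounds shown here, 4-chloro-3-(trifluoromethyl)phenyl in place of 4-methylphenyl on a saturated chain carbon bound to an amide-type nitrogen gives a 1.1-fold lower number from compound 2 to compound 3 (0.05 log units; within the scatter), the first comparison in this set that isolates a single place. At this position, the exchange, bringing in chlorine and fluorine, leaves compound 2 and compound 3 indistinguishable on this read-out, so this change to the benzyl group alone does not separate them. Nothing available bears on why the two numbers lie so close together.

The step carries the chlorine and the trifluoromethyl group together, so the compounds shown cannot tell what either would do alone, or whether the two contribute at all. Going by these compounds, it also remains open whether something other than a substituted phenyl ring at this place, such as an amine or a carboxylic acid, or a longer chain leading to the ring, would move the number beyond the scatter.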